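The compounds below may be only part of what the source reports. "The series", "measured", "known", "first", "only" and "open" are said of these compounds alone.

Three members of the series share one core and differ only in the group on the ring nitrogen of the saturated six-membered ring. In a functional assay on DU-145 cells (Homo sapiens) for cytotoxicity, read by sulforhodamine B assay, with a stated time of 48 h (on this read-out lower numbers stand for higher toxicity in this test and higher numbers for lower toxicity in this test), compound 1 `N#Cc1ccc(Nc2nc(Oc3ccnc4ccccc34)nc(N3CCCCC3)n2)cc1C(F)(F)F` reaches only the limit of the assay, > 100000 nM, not a number. Compound 2 `N#Cc1ccc(Nc2nc(Oc3ccnc4ccccc34)nc(N3CCN(c4ncccn4)CC3)n2)cc1C(F)(F)F` likewise gives only the limit > 100000 nM in this assay. Compound 3 `N#Cc1ccc(Nc2nc(Oc3ccnc4ccccc34)nc(N3CCN(C(c4ccccc4)c4ccc(Cl)cc4)CC3)n2)cc1C(F)(F)F` also sits at the limit, > 100000 nM, in this assay. The step that the two limits leave unreadable from compound 1 to compound 2 is therefore not readable in size, and compound 2 stands, like every measured member, at the limit (the limit of > 100000 nM in this assay, at which 3 of the 3 values shown sit).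

Compound 4 `N#Cc1ccc(Nc2nc(Oc3ccnc4ccccc34)nc(N3CCN(c4cccc(C(F)(F)F)c4)CC3)n2)cc1C(F)(F)F` is not yet measured. Its change from compound 2 is 3-(trifluoromethyl)phenyl in place of pyrimidin-2-yl on an amine nitrogen in a ring. Going by the values given here, no measured step bears on a swap at this ring nitrogen in a readable way: the only step at this position, from compound 1 to compound 2, is hidden by the limit, and compound 3, carrying a different large group there, is equally at the limit. With all three measured compounds at the limit (the limit of > 100000 nM in this assay, at which 3 of the 3 values shown sit), compound 4 is expected to remain there too, with a step of a number no higher from compound 2 to compound 4 (the limit leaves the size open) of no readable size. The estimate for compound 4 in this assay is 100000 nM, within 30000 nM to 300000 nM, most likely reported again as a limit rather than a number.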

Compound 4, concentration lethal to 50% of the cells: > 100000 nM
Compound 4 ended at the assay's limit; the forecaster's own chance of this, stated with the estimate: 80%; the middle value sits exactly at the limit.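

No new step can be read between compound 2 and compound 4 in this assay, as both results are limits of the assay and not numbers: the limit of > 100000 nM in this assay, at which 4 of the 4 values shown sit.

The compounds shown leave open whether any group at this ring nitrogen gives a numerical value, and how far the four compounds differ.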